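A few compounds are considered here, and "the series" means these few. Any claim that something is new, unique, unknown or untested is made for them only; others in the source may bear on it.

Working notes on the series. The read-out throughout is a functional assay on L132 cells (Homo sapiens) for cytotoxicity, read by MTT assay, with a stated time of 72 h; on this read-out lower numbers stand for an effect already at smaller amounts and higher numbers for an effect only at larger amounts of compound. Going by the values given here, compound 1 `O=C1/C(=C\c2cccc(Br)c2)c2ccccc2N1c1c(Cl)cccc1Cl` is the only one of the three compounds for which a single number stands: in this assay compound 1 gives 19 ug/mL. Compound 2 `Cc1ccc2nc(Cl)c(/C=C3\C(=O)N(c4c(Cl)cccc4Cl)c4ccccc43)cc2c1` has no result in this assay, the entry reading "not determined" (no result reported). For compound 3 `COc1ccc(/C=C2\C(=O)N(c3c(Cl)cccc3Cl)c3ccccc32)cc1OC` the entry in this assay is a limit and not a number, > 100 ug/mL. That entry sits at the limit of > 100 ug/mL in this assay, at which 1 of the 3 values shown sits. Among the compounds with values here, compound 1 therefore stands alone as the single measured point, with one limit beside it and one empty entry, and no step between two measured compounds is available for comparison.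

The next compound is compound 4 `O=C1/C(=C\c2ccccc2[N+](=O)[O-])c2ccccc2N1c1c(Cl)cccc1Cl`. The change from compound 1 is 2-nitrophenyl in place of 3-bromophenyl on a double-bonded chain carbon bound to a double-bonded ring carbon.

Within the data shown here, with no measured step to weigh this change against, the expectation rests on the single number for compound 1 alone. The step in this assay from compound 1 to compound 4 is expected to be a 1.6-fold higher number from compound 1 to compound 4 (0.20 log units; within the scatter), of a size that may not exceed the scatter, with a slight lean toward an effect only at larger amounts. For compound 4 the estimate in this assay is 30 ug/mL, expected to fall between 10 ug/mL and 100 ug/mL. A limit rather than a number is a real possibility for compound 4.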

Compound 4, concentration for half-maximal effect: 10 ug/mL
For compound 4 the middle estimate is 3.0-fold (0.48 log units) above the measured one, within the range that was stated.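

The series now has its first readable step in this assay, for 2-nitrophenyl in place of 3-bromophenyl on a double-bonded chain carbon bound to a double-bonded ring carbon, and it is a 1.9-fold lower number from compound 1 to compound 4 (0.28 log units; within the scatter). At this place, then, the exchange of one substituted phenyl for the other, with a nitro group entering and a bromine leaving, gives two values that cannot be told apart, so neither compound ranks over the other. Compound 3, with a different substituted phenyl at this place, gives a limit and not a number, and it remains the only such entry among the values shown: the limit of > 100 ug/mL in this assay, at which 1 of the 4 values shown sits.

Going by these compounds, what a phenyl carrying an amine or a carboxylic acid would give at this place stays open, as does whether 3-nitrophenyl would read like 2-nitrophenyl. Steps involving compound 2 or compound 3 cannot be read, so the single step available says nothing yet about how far this place can be changed before the read-out moves beyond the scatter.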